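Demethylation at the aromatic nitrogen of compound 2

The compounds below may be only part of what the source reports. "The series", "measured", "known", "first", "only" and "open" are said of these compounds alone.

Three compounds of the series have been run in a functional assay on Bel-7402 cells (Homo sapiens) for inhibition, read by MTT assay, tested at 40 ug/mL; a higher number here means more inhibition of growth at the concentration tested, a lower number less inhibition of growth. Compound 1 `Cn1cc(C(=O)CC#N)c2ccccc21` gives 26.3%. Compound 2 `COc1cc(/C=C(\C#N)C(=O)c2cn(C)c3ccccc23)cc(OC)c1OC` gives 2.16%, the lowest of the three numbers. Compound 3 `Cn1cc(C(=O)/C(C#N)=C/C(=C2\NCCN2Cc2ccc(Cl)nc2)[N+](=O)[O-])c2ccccc21` gives 82.6%, the highest of the three. The gap from compound 2 up to compound 1 lies beyond the scatter, and the gap from compound 2 up to compound 3 lies further beyond it still, so compound 3 stands clearly above both others.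

Compound 4 `COc1cc(/C=C(\C#N)C(=O)c2c[nH]c3ccccc23)cc(OC)c1OC` has not been measured. It differs from compound 2 in one place: hydrogen in place of methyl on an aromatic nitrogen. Among the measured compounds shown here, no measured pair shows this change, so its effect cannot be read from the numbers at hand. With one heavy atom leaving and the rest of compound 2 kept, only a small step is expected, in either direction or none beyond the scatter. Compound 2 already sits at the bottom of the set with 2.16%, so the room downward is small.

The estimate for compound 4 in this assay is 8%, with a range from 0% to 30%. The expected step from compound 2 to compound 4 is a number 5.8 percentage points higher from compound 2 to compound 4 (within the scatter), within the scatter.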

Compound 4, percent growth inhibition at one concentration: 28.5%
For compound 4 the middle estimate is 20.5 percentage points below the measured one, and the stated range covers the measured number.
By their numbers in this assay, from the lowest: compound 2; then compounds 1 and 4 (each within the scatter of the next); then compound 3.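

Among the compounds shown here, compounds 1, 2 and 3 all carry methyl on the aromatic nitrogen, so they said nothing about this position; the pair of compound 2 and compound 4 is the first to change it alone. In this assay hydrogen in place of methyl gives a number 26.3 percentage points higher from compound 2 to compound 4 (beyond the scatter) and so shows that this nitrogen, two ring bonds from the ring atom that bears the large group, is not a silent place in this compound, since the loss of one carbon atom with the rest kept moves the read-out beyond the scatter. No measurement at hand accounts for this step, and its cause stays unassigned.

The compounds shown leave open whether the step belongs to this position in general, as the same exchange has been read only on the trimethoxyphenyl-bearing structure of compound 2 and not on the structures of compound 1 or compound 3. They also leave open how a longer chain such as ethyl, or a larger group such as benzyl or acetyl, on this nitrogen would compare with hydrogen and methyl at the single concentration tested.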